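Removal of the aryloxy side chain from compound 1

A few compounds are considered here, and "the series" means these few. Any claim that something is new, unique, unknown or untested is made for them only; others in the source may bear on it.

Measured in this assay:
compound 1 `COc1ccc(-c2cc(-c3ccccc3)no2)c(OCC(O)CN2CCCCC2)c1` gives 17%
compound 2 `CCCCN(C)CCCOc1cc(OC)ccc1-c1cc(-c2ccccc2)no1` gives 15%
compound 3 `CCOC(=O)CCCOc1cc(OC)ccc1-c1cc(-c2ccccc2)no1` gives 4.6%

In a functional assay on the whole organism (blood, strain Charles Foster/Wistar albino) with Rattus norvegicus as the target, with a stated time of 30 min, at a dose of 100 mg/kg by the oral route (on this read-out lower numbers stand for less inhibition and higher numbers for more inhibition at the one dose given (going by the name of the read-out)), compound 1 stands highest of the three numbers. Against compound 2 the step is a number 2 percentage points lower from compound 1 to compound 2 (within the scatter); against compound 3 it is a number 12.4 percentage points lower from compound 1 to compound 3 (beyond the scatter). Compound 4 `COc1ccc(-c2cc(-c3ccccc3)no2)c(O)c1` is not yet measured; its change from compound 1 is hydrogen in place of 2-hydroxy-3-(piperidin-1-yl)propyl on an oxygen on an aromatic ring.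

Going by the values given here, no measured step removes the chain altogether. Among the compounds with values here, the steps that bear on it exchange an amine-bearing chain for an ethoxycarbonyl-bearing one: a number 12.4 percentage points lower from compound 1 to compound 3 (beyond the scatter) and a number 10.4 percentage points lower from compound 2 to compound 3 (beyond the scatter), both modest and beyond the scatter. A drop of similar size is therefore expected for compound 4, as a number 10 percentage points lower from compound 1 to compound 4 (within the scatter). Compound 4 is estimated at 7%, between 0% and 17%.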

Compound 4, a percentage reported as inhibition, in the whole organism at one dose (the size of the read-out at that dose, not a potency): 9.8%
For compound 4 the middle estimate is 2.8 percentage points below the measured one; measured number inside the range.
By their numbers in this assay, from the lowest: compounds 3, 4, 2 and 1 (each within the scatter of the next, the first and the last beyond it).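

In this assay, hydrogen on the oxygen on an aromatic ring stays within the scatter of every chain tested: (a number 7.2 percentage points lower from compound 1 to compound 4 (within the scatter)) and (a number 5.2 percentage points lower from compound 2 to compound 4 (within the scatter)) and (a number 5.2 percentage points higher from compound 3 to compound 4 (within the scatter)). The 2-hydroxy-3-(piperidin-1-yl)propyl chain is therefore not shown to be needed for this read-out, and the gap between compound 1 and compound 3 cannot be assigned to either chain as a gain or a loss against the unsubstituted oxygen. No available evidence explains this result. Open, going by these compounds, is whether a carboxylic acid at the chain end, or a morpholine ring in place of the piperidine, would move the number beyond the scatter of compound 4.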